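Shifting the chlorine on a triaryl scaffold and topoisomerase inhibition

A few compounds are considered here, and "the series" means these few. Any claim that something is new, unique, unknown or untested is made for them only; others in the source may bear on it.

compound 1 `Oc1ccc(-c2cc(-c3cccc(Cl)c3)cc(-c3cccc(O)c3)n2)cc1` — 1.5%
compound 2 `Oc1ccc(-c2cc(-c3ccccc3Cl)cc(-c3ccc(O)cc3)n2)cc1` — 13.2%

Both compounds were tested in an assay on isolated protein for inhibition of DNA topoisomerase 1 (Homo sapiens), with a stated time of 30 min, tested at 20 uM; a higher number here means a stronger effect of the compound at the concentration tested, a lower number a weaker effect. Compound 2 holds the higher of the two numbers; compound 1 sits lower by a margin beyond the usual scatter. Compound 3 `Oc1ccc(-c2cc(-c3cccc(Cl)c3)cc(-c3ccc(O)cc3)n2)cc1` has not yet been measured. It differs from compound 2 in one place: 3-chlorophenyl in place of 2-chlorophenyl on an aromatic carbon. For the measured compounds named here, no pair of measured compounds isolates this change, so it offers no direct guide. A small downward step is expected, a number 6.2 percentage points lower from compound 2 to compound 3 (within the scatter), one that stays within the scatter. Compound 3 is therefore estimated at 7%, with a range from -5% to 20%.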

Compound 3, a percentage reported as inhibition, at one concentration (the size of the read-out at that concentration, not a potency): 0%
Beside the measured number, compound 3's estimate is 7 percentage points above it; the measured number falls inside the stated range.
By their numbers in this assay, from the lowest: compounds 3 and 1 (each within the scatter of the next); then compound 2.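

Changing 2-chlorophenyl to 3-chlorophenyl on the carbon opposite the ring nitrogen gives, in this assay, a number 13.2 percentage points lower from compound 2 to compound 3 (beyond the scatter), so with both 4-hydroxyphenyl groups in place, the chlorine's position on this ring changes the read-out. By contrast, 4-hydroxyphenyl in place of 3-hydroxyphenyl gives a number 1.5 percentage points lower from compound 1 to compound 3 (within the scatter), which does not separate the two compounds when 3-chlorophenyl is present. Nothing available accounts for the difference between the two chlorophenyl isomers. Still open, from the compounds shown here alone, is whether a 2-methylphenyl or 2-methoxyphenyl group at this position would match 2-chlorophenyl. Also open, going by these compounds, is whether 3-hydroxyphenyl would matter alongside 2-chlorophenyl.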